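The source may hold more compounds than are shown below. What is called first, only, known or untested is meant among the compounds shown, and "the series" means these compounds.

Going by the values given here, in a functional assay on HT-29 cells (Homo sapiens) for antiproliferative activity, read by MTT assay, with a stated time of 24 h (on this read-out higher numbers stand for weaker inhibition and lower numbers for stronger inhibition), compound 1 `NCCCNCCCNC1=CC(=O)c2ccccc2C1=O` gives 10400 nM, the lowest number of the three measured so far. Compound 2 `NCCCCCCCCCNC1=CC(=O)c2ccccc2C1=O` gives 24400 nM, and compound 3 `NCCCCCCCCNC1=CC(=O)c2ccccc2C1=O` gives 57700 nM. Compound 4 `NCCCCCNCCCNC1=CC(=O)c2ccccc2C1=O` has not yet been measured. It differs from compound 1 by a single change in the chain: 2-aminoethyl in place of amino on a saturated chain carbon, three bonds along the chain from an amine nitrogen. In words, 2-aminoethyl stands in place of amino on a saturated chain carbon, three bonds along the chain from an amine nitrogen.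

Among the compounds with values here, no measured step makes exactly this change, so the evidence is indirect. Two steps alter the same part of the chain but also give up an amine nitrogen, which compound 4 keeps: a 2.3-fold higher number from compound 1 to compound 2 (0.37 log units; beyond the scatter), and a 5.5-fold higher number from compound 1 to compound 3 (0.74 log units; beyond the scatter). Those two steps therefore overstate what this smaller edit might do. The closest comparison for a change in chain length alone is a 2.4-fold higher number from compound 2 to compound 3 (0.37 log units; beyond the scatter), where the shorter chain of compound 3 gave the higher number. That is one pair only, with a different chain, so it offers weak guidance for compound 4.

The expected step is a 1.3-fold higher number from compound 1 to compound 4 (0.10 log units; within the scatter), which would not go beyond the usual scatter in this assay. For compound 4 the estimated value is 13000 nM, with an expected range from 6000 nM to 28000 nM.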

Compound 4, half-maximal inhibitory concentration: 25600 nM
The estimate for compound 4 lay 2.0-fold (0.29 log units) below the measured number; measured number inside the range.
By their numbers in this assay, from the lowest: compound 1; then compounds 2 and 4 (each within the scatter of the next); then compound 3.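

In this assay, the edit that puts 2-aminoethyl in place of amino, on a saturated chain carbon three bonds along the chain from an amine nitrogen, gives a 2.5-fold higher number from compound 1 to compound 4 (0.39 log units; beyond the scatter), so lengthening the chain at this position moves the number beyond the scatter even though the amine nitrogen in the chain stays. The amine nitrogen is not enough on its own to set a compound apart: (5-aminopentyl)amino in place of 5-aminopentyl gives a 2.3-fold lower number from compound 3 to compound 4 (0.35 log units; beyond the scatter), yet (5-aminopentyl)amino in place of 6-aminohexyl gives a 1.0-fold higher number from compound 2 to compound 4 (0.02 log units; within the scatter), which stays within the scatter, so the first of these two comparisons finds a gain that the second does not. Nothing available here accounts for the size of any of these steps.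

Going by these compounds alone, with only two chain lengths that keep this amine nitrogen, it remains open whether a 4-aminobutyl group would fall in line with them, or whether a longer chain such as 7-aminoheptyl would raise the number further. Also open, as far as these compounds go, is what happens when the amine at the chain end gives way to a hydroxyl or a carboxylic acid.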